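Swapping one phenyl group for another

The source may report more compounds than this note shows. Statements on the series, on what has been measured and on what is new or still open speak of the compounds shown alone.

In a functional assay on MDA-MB-231 cells (Homo sapiens) for antiproliferative activity, read by MTT assay, with a stated time of 72 h (a higher number here means a weaker inhibitor, a lower number a stronger inhibitor), compound 1 `CCn1ccnc1-c1cc(OC)c(OC)c(OC)c1` gives > 100000 nM as a limit and not a number. Within the data shown here, compound 2 `COc1cc(-c2nccn2-c2cccc(C)c2)cc(OC)c1OC` gives 11700 nM and so holds the only true number so far. Among the measured compounds shown here, the one measured step is an at least 8.5-fold lower number from compound 1 to compound 2 (0.93 log units; beyond the scatter) and it is the only guide here. Compound 3 `COc1cc(-c2nccn2-c2ccc(Br)cc2)cc(OC)c1OC` differs from compound 2 in one group: 4-bromophenyl in place of 3-methylphenyl on an aromatic nitrogen is the whole change. That measured step replaced ethyl, whereas this change swaps one substituted phenyl for another, so no step beyond the scatter is expected. In this assay the expected change is a 1.5-fold lower number from compound 2 to compound 3 (0.17 log units; within the scatter) by this estimate. Compound 3 is expected at 8000 nM with a range from 1500 nM to 40000 nM as estimated here.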

Compound 3, half-maximal inhibitory concentration: 8400 nM
Estimate against measurement, compound 3: 1.1-fold (0.02 log units) below, and the stated range covers the measured number.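

In this assay, replacing 3-methylphenyl with 4-bromophenyl on the aromatic nitrogen gives a 1.4-fold lower number from compound 2 to compound 3 (0.14 log units; within the scatter), so these two substituted phenyl groups cannot be told apart here. Against ethyl, the second phenyl compound also shows an at least 11-fold lower number from compound 1 to compound 3 (1.07 log units; beyond the scatter), so the drop seen with compound 2 recurs with a different phenyl group. The true size of both steps from ethyl stays unknown, because compound 1 gives only a limit: the limit of > 100000 nM in this assay, at which 1 of the 3 values shown sits.

Still open, as far as these compounds go, is how an unsubstituted phenyl, a phenyl carrying an amine or a carboxylic acid, or a longer alkyl chain would compare on this nitrogen.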